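The source may report more compounds than this note shows. Statements on the series, on what has been measured and on what is new or still open speak of the compounds shown alone.

Measured compounds in a functional assay on HL-60 cells (Homo sapiens) for inhibition, read by MTT assay, with a stated time of 72 h, tested at 50 uM; a lower number here means less inhibition of growth, a higher number more inhibition of growth at the concentration tested:

compound 1 `C=CCc1ccc(OCc2cn(-c3ccccc3CO)nn2)c(O)c1` gives 47.1%
compound 2 `C=CCc1cc(O)c(O)c(CN2CCC(CO)CC2)c1` gives 43.3%
compound 3 `C=CCc1ccc(OCc2cn(-c3ccccc3Cl)nn2)c(O)c1` gives 43.2%

Going by the values given here, of the three numbers, the one for compound 3 is the lowest, but its distance to compound 2 and its distance to compound 1 are both within the scatter, so the three compounds cannot be told apart in this assay. Among the compounds with values here, the only step between compounds that differ in one place, a number 3.9 percentage points lower from compound 1 to compound 3 (within the scatter), is likewise within the scatter.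

Compound 4 `C=CCc1ccc(OCc2cn(-c3cccc(C#N)c3)nn2)c(O)c1` has not been measured. It differs from compound 3 as follows: 3-cyanophenyl in place of 2-chlorophenyl on an aromatic nitrogen. Within the data shown here, the one measured step, from compound 1 to compound 3, changed a single substituent on the ring attached to that aromatic nitrogen and moved the number by less than the scatter; no measured pair exchanges the whole ring, so nothing here points to a change beyond the scatter. The expectation is therefore a step of about a number 0.2 percentage points lower from compound 3 to compound 4 (within the scatter), essentially none. Compound 4 is estimated at 43%, with a range from 28% to 58%.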

Compound 4, percent growth inhibition at one concentration: 30.9%
Compound 4: middle estimate off by 12.1 percentage points, on the high side; low and high end bracket the measured number.
By their numbers in this assay, from the lowest: compound 4; then compounds 3, 2 and 1 (each within the scatter of the next).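

In this assay, the ring on the aromatic nitrogen of the five-membered aromatic ring is now a place where a change moves the number beyond the scatter: 3-cyanophenyl in place of 2-chlorophenyl gives a number 12.3 percentage points lower from compound 3 to compound 4 (beyond the scatter), and 3-cyanophenyl in place of 2-(hydroxymethyl)phenyl gives a number 16.2 percentage points lower from compound 1 to compound 4 (beyond the scatter). The exchange of 2-(hydroxymethyl)phenyl for 2-chlorophenyl gave only a number 3.9 percentage points lower from compound 1 to compound 3 (within the scatter), so these two groups cannot be told apart here, while the 3-cyanophenyl group separates from both. Nothing available accounts for the lower number in compound 4.

The step changes both the group and where it sits on the ring, so the compounds shown cannot say which of the two goes with the lower number; a 2-cyanophenyl or a 3-chlorophenyl group on the same aromatic nitrogen would separate them. Also open, going by these compounds, is whether the lower number is specific to the nitrile or extends to other groups at the same place, such as an amine or a carboxylic acid.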